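Trifluoromethylbenzyl sulfanyl change on the shared core

This account rests on a few compounds, and the source may have more. Where it says the series, first, only, none or still open, it means among the compounds named here.

Measured compounds:
compound 1, `Cc1cc(-c2ccccc2)n(/C(N)=N/S(=O)(=O)c2cc(C)c(Cl)cc2SCc2cccc(C(F)(F)F)c2)n1`: 19000 nM
compound 2, `Cc1cc(-c2ccccc2)n(/C(N)=N/S(=O)(=O)c2cc(C)c(Cl)cc2SCc2ccccc2C)n1`: 42000 nM
compound 3, `Cc1cc(S(=O)(=O)/N=C(\N)n2nccc2-c2ccccc2)c(SCc2ccccc2C)cc1Cl`: 16000 nM

All three were run in a functional assay on HCT-116 cells (Homo sapiens) for cytotoxicity, read by MTT assay, with a stated time of 72 h; a lower number here means a stronger inhibitor, a higher number a weaker inhibitor. Compound 2 gives the highest of the three numbers; compound 3 gives the lowest, and compound 1 lies within the scatter of compound 3, so no order between those two is claimed.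

Two changes have been made from compound 2. The first, (3-(trifluoromethyl)phenyl in place of 2-methylphenyl on a saturated chain carbon bound to a sulfur), gave a 2.2-fold lower number from compound 2 to compound 1 (0.34 log units; beyond the scatter). The second, (hydrogen in place of methyl on an aromatic carbon), gave a 2.6-fold lower number from compound 2 to compound 3 (0.42 log units; beyond the scatter); this is also how the core of compound 3 differs from the core of compound 2.

Compound 4, `Cc1cc(S(=O)(=O)/N=C(\N)n2nccc2-c2ccccc2)c(SCc2cccc(C(F)(F)F)c2)cc1Cl`, has not yet been measured in this assay. It differs from compound 3 by 3-(trifluoromethyl)phenyl in place of 2-methylphenyl on a saturated chain carbon bound to a sulfur. The place line of this change matches word for word the place line of the change from compound 2 to compound 1, so it is the same change made on the other core.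

Going by the values given here, for compound 4 a step of a 2.0-fold lower number from compound 3 to compound 4 (0.30 log units; within the scatter) in this assay is expected because a 2.2-fold lower number from compound 2 to compound 1 (0.34 log units; beyond the scatter) is the only measured instance of this change and rests on a single pair. With compound 3 at 16000 nM, compound 4 is estimated at 8000 nM, between 4000 nM and 20000 nM.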

Compound 4, half-maximal inhibitory concentration: 14000 nM
Estimate against measurement, compound 4: 1.8-fold (0.24 log units) below; low and high end bracket the measured number.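

Carried onto the other core in this assay, the change to 3-(trifluoromethyl)phenyl gives a 1.1-fold lower number from compound 3 to compound 4 (0.06 log units; within the scatter), and hydrogen in place of methyl on an aromatic carbon, read on the second pair, gives a 1.4-fold lower number from compound 1 to compound 4 (0.13 log units; within the scatter), so neither new step on its own shows a change in the number. For the change on the saturated chain carbon bound to a sulfur, the two readings do not differ: the same change on two cores in this assay, a 2.2-fold lower number (0.34 log units; beyond the scatter) from compound 2 to compound 1 and a 1.1-fold lower number (0.06 log units; within the scatter) from compound 3 to compound 4, 1.9-fold (0.29 log units) apart, within the scatter of two such steps. The methyl change reads the same way, so neither change is shown to depend on the core, although a single pair per core cannot show that either step keeps its size on further cores: the same change on two cores in this assay, a 2.6-fold lower number (0.42 log units; beyond the scatter) from compound 2 to compound 3 and a 1.4-fold lower number (0.13 log units; within the scatter) from compound 1 to compound 4, 1.9-fold (0.29 log units) apart, within the scatter of two such steps.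

The compounds shown leave open how the series responds to a carboxylic acid or an amine on the benzyl group, or to a longer chain on the sulfur in its place. As far as these compounds go, whether either change carries over in any read-out other than this assay also stays open.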